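The source may report more compounds than this note shows. Statements on the series, on what has been measured and on what is new or still open speak of the compounds shown alone.

Compound 1 `Cc1ccc(/C=C2\CCC/C(=C\c3cccc([N+](=O)[O-])c3)C2=O)cc1` was tested in a functional assay on CCRF-CEM cells (Homo sapiens) for cytotoxicity, with a stated time of 72 h (a lower number here means a stronger inhibitor, a higher number a weaker inhibitor), where compound 1 gives 10100 nM. Among the measured compounds shown here, the only other measured compound in the set, compound 2 `O=C1CCCC/C1=C\c1ccc([N+](=O)[O-])cc1`, gives 19300 nM in this assay, and the two numbers lie within the usual scatter of each other, so no order between them can be drawn. Compound 3 `O=C1/C(=C/c2ccc(F)cc2)CCC/C1=C\c1cccc([N+](=O)[O-])c1` has not yet been measured in this assay. It differs from compound 1 in one place: fluoro in place of methyl on an aromatic carbon. For the measured compounds named here, no step between two measured compounds in this set shows what such a change does, so the expectation rests on the structural change alone. A change of this size and kind is expected to move the number by a step no larger than the scatter, in no clear direction, which is what a 1.0-fold lower number from compound 1 to compound 3 (0.00 log units; within the scatter) expresses. Compound 3 is therefore estimated to give 10000 nM in this assay, with the range 4000 nM to 25000 nM.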

Compound 3, half-maximal inhibitory concentration: 5050 nM
Estimate against measurement, compound 3: 2.0-fold (0.30 log units) above, and the stated range covers the measured number.
By their numbers in this assay, from the lowest: compounds 3, 1 and 2 (each within the scatter of the next, the first and the last beyond it).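

In this assay, among the compounds shown here, putting 4-fluorophenyl in place of 4-methylphenyl gives a 2.0-fold lower number from compound 1 to compound 3 (0.30 log units; within the scatter) and so provides the first reading of a single change in this set, at an aromatic carbon para to a large group. This place therefore takes fluoro in place of methyl without a step beyond the usual scatter, so this one exchange does not separate the two groups. Nothing measured here speaks to why the two groups read alike.

From the compounds shown here alone, it remains open whether a larger or charged group at the same place, such as an amine or a carboxylic acid, would give a step beyond the scatter. Compound 2 differs from the others in more than one place, so the compounds shown also leave open what the second arylidene group or the nitro group contributes on its own.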